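The source may hold more compounds than are shown below. What is called first, only, known or untested is meant among the compounds shown, and "the series" means these compounds.

The study begins with three compounds built on one shared core. Compound 1 `OCCCCC#Cc1ccccc1C#Cc1cccc(O)c1` and compound 2 `OCCCCC#Cc1ccccc1C#Cc1cccc(C(F)(F)F)c1` differ only in that (trifluoromethyl in place of hydroxy on an aromatic carbon), while compound 3 `OCCCCC#Cc1ccccc1C#Cc1ccc(O)cc1` carries a hydroxy-bearing ring joined otherwise, so that (4-hydroxyphenyl in place of 3-hydroxyphenyl on a triple-bonded carbon). In a functional assay on MDA-MB-435 cells (Homo sapiens) for cytotoxicity (on this read-out lower numbers stand for stronger inhibition of growth and higher numbers for weaker inhibition of growth), compound 1 gives 16100 nM. In this assay compound 2 gives 16900 nM, and the step of a 1.0-fold higher number from compound 1 to compound 2 (0.02 log units; within the scatter). In this assay compound 3 gives 16100 nM, and the step of no change at the digits printed from compound 1 to compound 3 (within the scatter).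

The unmeasured compound 4 `OCCCCC#Cc1ccccc1C#Cc1ccc(C(F)(F)F)cc1` is reached from compound 3 by the change (trifluoromethyl in place of hydroxy on an aromatic carbon). This is the same kind of change as that from compound 1 to compound 2, not the same: there the group sat meta to a large group, here it sits para to a large group.

The step of a 1.1-fold higher number from compound 3 to compound 4 (0.02 log units; within the scatter) is expected to be small. Among the measured compounds shown here, that expectation rests on the step of a 1.0-fold higher number from compound 1 to compound 2 (0.02 log units; within the scatter), the only measured example of this kind of change. Compound 4 is therefore estimated to give 17000 nM, between 9000 nM and 34000 nM.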

Compound 4, concentration for 50% growth inhibition: 16300 nM
Compound 4: the middle estimate sits 1.0-fold (0.02 log units) above what was measured; the range from low to high includes it.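

In this assay, the swap of hydroxy for trifluoromethyl, here para to a large group, gives a 1.0-fold higher number from compound 3 to compound 4 (0.01 log units; within the scatter), and so this second example of the change matches the first: the same change on two cores in this assay, a 1.0-fold higher number (0.02 log units; within the scatter) from compound 1 to compound 2 and a 1.0-fold higher number (0.01 log units; within the scatter) from compound 3 to compound 4, 1.0-fold (0.02 log units) apart, within the scatter of two such steps. Within this small set, then, the change carries from the core of compound 1 to the core of compound 3 without any step that can be told from the scatter, whichever of the two hydroxy-bearing rings it starts from. This does not show that a real effect transfers between cores, as both steps lie within the scatter, and two pairs in a single cell line cannot establish a rule for the wider series.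

The compounds shown leave open whether an amine or a carboxylic acid on the same aromatic ring would move the number at all. They also leave open what a longer chain would do in place of the hydroxy-bearing chain that all four compounds share.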